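The source may report more compounds than this note shows. Statements on the series, on what has been measured and on what is new or still open speak of the compounds shown alone.

Working notes on the series. In a functional assay on KB cells (Homo sapiens) for antiproliferative activity, read by sulforhodamine B assay, with a stated time of 72 h (on this read-out higher numbers stand for weaker inhibition and lower numbers for stronger inhibition), compound 1 `COc1ccc(/C=C2\CCC=CC2=O)cc1` gives 1560 nM, compound 3 `CC(=O)n1cc(/C=C2\CCC=CC2=O)c2ccccc21` gives 4460 nM, and compound 2 `O=C1C=CCC/C1=C\c1ccc(OC(F)(F)F)cc1` gives 530 nM, the lowest of the three numbers. Next is compound 4 `O=C1C=CCC/C1=C\c1ccc(-c2ccccc2)cc1`, with phenyl in place of trifluoromethoxy on an aromatic carbon. Among the compounds with values here, only one measured step bears on this place, a 2.9-fold lower number from compound 1 to compound 2 (0.47 log units; beyond the scatter), and it is modest and involves no ring entering. Compound 3, with a larger aromatic group on the shared core, stands at 4460 nM, so a modest move to a higher number is expected in this assay. The expected step is a 2.5-fold higher number from compound 2 to compound 4 (0.39 log units; beyond the scatter). For compound 4 the estimated value is 1300 nM, with an expected range of 450 nM to 3800 nM.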

Compound 4, half-maximal inhibitory concentration: 2320 nM
For compound 4 the middle estimate is 1.8-fold (0.25 log units) below the measured one; the measured number falls inside the stated range.
By their numbers in this assay, from the lowest: compound 2; then compounds 1, 4 and 3 (each within the scatter of the next, the first and the last beyond it).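

At this place on the aromatic ring, the gain seen with trifluoromethoxy does not carry over to every replacement in this assay: phenyl in its place gives a 4.4-fold higher number from compound 2 to compound 4 (0.64 log units; beyond the scatter) and so stands clearly apart from it. Phenyl in place of methoxy gives a 1.5-fold higher number from compound 1 to compound 4 (0.17 log units; within the scatter) and so a ring entering here leaves the number level with methoxy. No evidence is at hand that explains either step. From the compounds shown here alone, whether an amine or a carboxylic acid at this place would stay level with methoxy and phenyl or reach trifluoromethoxy remains open.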